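Cyano in Place of Methoxy: Expecting the Next Value

The source may hold more compounds than are shown below. What is called first, only, known or untested is meant among the compounds shown, and "the series" means these compounds.

The measured compounds so far:
compound 1 `CNCCN(C)c1nnnn1Cc1ccc(C#N)cc1` with 6%,
compound 2 `CNCCN(C)c1nnnn1Cc1ccc(OC)cc1` with 0%,
compound 3 `CNCCN(C)Cc1ccc(-c2cccc(OC)c2)o1` with 37%.

In an assay on cells for inhibition of protein arginine N-methyltransferase 1 (Homo sapiens), read by scintillation counting, with stated times of 15 min and 60 min, tested at 9 uM (on this read-out lower numbers stand for less inhibition and higher numbers for more inhibition at the one concentration tested (going by the name of the read-out)), compound 2 gives 0%. Compound 1 carries the change (cyano in place of methoxy on an aromatic carbon). The step is a number 6 percentage points higher from compound 2 to compound 1 (within the scatter), so the two values cannot be told apart.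

Compound 3 stands on a different core, and the difference between the two cores is not broken down here. In this assay compound 3 gives 37%, the highest of the three numbers, and its distance to both of the others is beyond the usual scatter.

Compound 4 `CNCCN(C)Cc1ccc(-c2cccc(C#N)c2)o1` has not been measured. It differs from compound 3 by cyano in place of methoxy on an aromatic carbon. Among the measured compounds shown here, this is the same kind of change as the one from compound 2 to compound 1, though not the same: in compound 1 the cyano sits para to a large group, whereas in compound 4 it sits meta to a large group.

For the measured compounds named here, only one measured example of this kind of change exists, and it moved the value by a number 6 percentage points higher from compound 2 to compound 1 (within the scatter). On that basis the step from compound 3 to compound 4 is expected to be small, about a number 1 percentage points higher from compound 3 to compound 4 (within the scatter). For compound 4 the estimated value in this assay is 38%, with a likely range from 22% to 54%.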

Compound 4, a percentage reported as inhibition, at one concentration (the size of the read-out at that concentration, not a potency): 33%
Beside the measured number, compound 4's estimate is 5 percentage points above it; measured number inside the range.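

In this assay, putting cyano in place of methoxy gives a number 4 percentage points lower from compound 3 to compound 4 (within the scatter), and the two values cannot be told apart. Set beside the earlier example, the change reads the same on both cores as far as this measurement can tell: the same change on two cores in this assay, a number 6 percentage points higher (within the scatter) from compound 2 to compound 1 and a number 4 percentage points lower (within the scatter) from compound 3 to compound 4, 10 percentage points apart, within the scatter of two such steps. This shows that in these two pairs the swap from methoxy to cyano leaves no readable mark on the result, and that the near-zero numbers of the first pair and the clearly higher numbers of the second do not make the step look different; it does not show that the swap would be silent on a third core, and it rests on two pairs tested at one concentration, which gives the size of the read-out and not a potency.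

The compounds shown carry only methoxy or cyano at the changed place, which leaves open how an amine, a carboxylic acid or a fluorine atom there would read on the core of compound 3. Also open, on these data alone, is what a longer chain would do in place of the side chain that all four compounds share.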